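Isopropyl to 3-hydroxypropyl: an expected small step

The source may report more compounds than this note shows. Statements on the series, on what has been measured and on what is new or still open speak of the compounds shown alone.

In a functional assay on MCF7 cells (Homo sapiens) for antiproliferative activity, read by MTT assay, with a stated time of 24 h (on this read-out higher numbers stand for weaker inhibition and lower numbers for stronger inhibition), the measured compounds are:
Compound 1 `CCn1c(C(=O)NC2(CO)CC2)ccc1C(CC)(CC)c1ccc(OCS(=O)(=O)c2ccccc2)c(C)c1` gives 28800 nM
Compound 2 `CCn1c(C(=O)N[C@@H](CO)C(C)C)ccc1C(CC)(CC)c1ccc(OCS(=O)(=O)c2ccccc2)c(C)c1` gives 18800 nM

Compound 2 stands level with compound 1 on these two numbers, and neither can be ranked over the other. The measured step between them is a 1.5-fold lower number from compound 1 to compound 2 (0.19 log units; within the scatter) and that gap is no larger than repeat measurements of one compound would give.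

In compound 3 `CCn1c(C(=O)N[C@@H](CO)CCCO)ccc1C(CC)(CC)c1ccc(OCS(=O)(=O)c2ccccc2)c(C)c1` 3-hydroxypropyl takes the place of isopropyl on a saturated chain carbon bound to an amide-type nitrogen and a saturated chain carbon. The change counts as 3-hydroxypropyl in place of isopropyl on a saturated chain carbon bound to an amide-type nitrogen and a saturated chain carbon and is the only one.

Within the data shown here, the sole guide is the measured step above, which also alters the group on the amide-type nitrogen and stays within the scatter. Among the measured compounds shown here, no measured compound carries 3-hydroxypropyl, and the evidence is thin. In this assay no step beyond the scatter is expected, in either direction. An estimated 1.2-fold higher number from compound 2 to compound 3 (0.07 log units; within the scatter) is what this reasoning gives. For compound 3 the estimated value is 22000 nM with an expected range from 10000 nM to 50000 nM as the likely span.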

Compound 3, half-maximal inhibitory concentration: 29600 nM
The estimate for compound 3 lay 1.3-fold (0.13 log units) below the measured number; low and high end bracket the measured number.
By their numbers in this assay, from the lowest: compounds 2, 1 and 3 (each within the scatter of the next).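

In this assay, 3-hydroxypropyl in place of isopropyl on a saturated chain carbon bound to an amide-type nitrogen and a saturated chain carbon gives a 1.6-fold higher number from compound 2 to compound 3 (0.20 log units; within the scatter), so a group with 1 hydrogen-bond donor and 1 hydrogen-bond acceptor stands here in place of one with neither, and the step stays within the scatter. A wider exchange on the amide-type nitrogen, a group of 7 heavy atoms with no ring in place of a group of 5 heavy atoms with a three-membered ring, gives a 1.0-fold higher number from compound 1 to compound 3 (0.01 log units; within the scatter), which also stays within the scatter. No measurement at hand offers a reason for these small steps.

As far as these compounds go, it remains open whether any group on this carbon can move the number beyond the scatter, in either direction. An amine, a carboxylic acid or a chain longer than 3-hydroxypropyl in this place would put that question to the test in this assay.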